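The compounds below may be only part of what the source reports. "The series", "measured", "known", "first", "only" and "open" are said of these compounds alone.

Measured compounds: compound 1 `O=C(NC1CCCCC1)c1c(NO)cc(-c2ccc(Cl)cc2)oc1=O` gives 8800 nM in an ADME assay on Huh-7 cells (Homo sapiens) for cytotoxicity, with a stated time of 3 days; a lower number here means that less compound is tolerated, a higher number that more compound is tolerated; compound 2 `O=C(Nc1ccc(Cl)cc1)c1c(NCCO)cc(-c2cccc(Br)c2)oc1=O` gives 17000 nM in this assay.

Compound 3 `O=C(Nc1ccc(Cl)cc1)c1c(NCCO)cc(-c2ccc(Br)cc2)oc1=O` shows in this assay only a limit of the assay, > 20000 nM, not a number. For the measured compounds named here, the one measured step, an at least 1.1-fold higher number from compound 2 to compound 3 (0.07 log units; that floor lies within the scatter), is therefore a floor rather than a fixed size, as seen in the limit of > 20000 nM in this assay, at which 1 of the 3 values shown sits.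

Compound 4 `COc1ccccc1NC(=O)c1c(NCCO)cc(-c2ccc(Br)cc2)oc1=O` differs from compound 3 in 2-methoxyphenyl in place of 4-chlorophenyl on an amide-type nitrogen. That measured step concerns the other aromatic ring, not the amide-type nitrogen, so nothing shown bears on this change. With compound 3 at the limit, compound 4 is expected to stay near it, a step of a number no higher from compound 3 to compound 4 (the limit leaves the size open). The estimate for compound 4 is 20000 nM, between 8000 nM and 40000 nM.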

Compound 4, half-maximal cytotoxic concentration: > 20000 nM
Compound 4 gave a limit, no number; the forecaster's own chance of this, stated with the estimate: 60%; the middle value sits exactly at the limit.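

Compound 3 and compound 4 both stand only at a limit in this assay, so no step between them can be read: the limit of > 20000 nM in this assay, at which 2 of the 4 values shown sit.

The compounds shown leave open whether 2-methoxyphenyl in place of 4-chlorophenyl on the amide-type nitrogen changes the number at all.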